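Swapping Nitrile for Nitro on Two Related Cores

The source may hold more compounds than are shown below. What is called first, only, known or untested is meant among the compounds shown, and "the series" means these compounds.

Three compounds share an amide that joins a hydroxy-bearing chain to a substituted benzene ring. Compound 1, `CC(O)(CSc1ccc(S(F)(F)(F)(F)F)cc1)C(=O)Nc1ccc(C#N)c(C(F)(F)F)c1`, carries a thioether in the chain and a cyano group on the ring. Compound 2, `CC(O)(CSc1ccc(S(F)(F)(F)(F)F)cc1)C(=O)Nc1ccc([N+](=O)[O-])c(C(F)(F)F)c1`, keeps that core but bears a nitro group instead. Compound 3, `CC(O)(CS(=O)(=O)c1ccc(S(F)(F)(F)(F)F)cc1)C(=O)Nc1ccc(C#N)cc1C(F)(F)F`, has a sulfone in the chain and its trifluoromethyl group placed differently; the difference between the core of compound 1 and the core of compound 3 is not broken down here.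

In a functional assay on VCaP cells (Homo sapiens) for antiproliferative activity, read by propidium iodide staining, with a stated time of 96 h (a lower number here means a stronger inhibitor, a higher number a weaker inhibitor), compound 1 gives 30200 nM. In this assay compound 2 gives 10100 nM. Compound 3 gives 43000 nM in this assay. The change from compound 1 to compound 2, (nitro in place of cyano on an aromatic carbon), made a 3.0-fold lower number from compound 1 to compound 2 (0.48 log units; beyond the scatter). Compound 1 and compound 3 lie within the scatter of each other, while compound 2 stands below compound 3 by a gap beyond the scatter.

Compound 4, `CC(O)(CS(=O)(=O)c1ccc(S(F)(F)(F)(F)F)cc1)C(=O)Nc1ccc([N+](=O)[O-])cc1C(F)(F)F`, has not yet been measured in this assay. It differs from compound 3 by nitro in place of cyano on an aromatic carbon. Among the compounds with values here, this is the same kind of change as the one from compound 1 to compound 2, not the same: in compound 1 the group sits ortho to a trifluoromethyl group, in compound 3 meta to it.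

Within the data shown here, the expectation for compound 4 rests on the single earlier step, because a 3.0-fold lower number from compound 1 to compound 2 (0.48 log units; beyond the scatter) is the only precedent for this swap. The estimated step is a 2.9-fold lower number from compound 3 to compound 4 (0.46 log units; beyond the scatter). Compound 4 is expected to give about 15000 nM in this assay, most likely between 6000 nM and 40000 nM.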

Compound 4, half-maximal inhibitory concentration: 28600 nM
Compound 4: middle estimate off by 1.9-fold (0.28 log units), on the low side; the measured number falls inside the stated range.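

In this assay, nitro in place of cyano on the second core gave a 1.5-fold lower number from compound 3 to compound 4 (0.18 log units; within the scatter), so on this core the swap has no effect that can be told apart from the ordinary spread of repeated measurements. Set beside the earlier step on the thioether core, the new step does not differ from it by more than that spread, so the results are compatible with the swap carrying over from one core to the other: the same change on two cores in this assay, a 3.0-fold lower number (0.48 log units; beyond the scatter) from compound 1 to compound 2 and a 1.5-fold lower number (0.18 log units; within the scatter) from compound 3 to compound 4, 2.0-fold (0.30 log units) apart, within the scatter of two such steps. Within the data shown here, this does not show that the swap acts identically on both cores, since only two steps are available, one beyond the scatter and one within it, and a modest real difference between them would go unseen at this level of precision.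

The compounds shown leave open how a group other than cyano or nitro, such as an amine or a carboxylic acid, would behave in that same place on either core. They also leave open how the thioether and the sulfone would each compare with the trifluoromethyl group held in one place, as the two cores differ in both features at once.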